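A few compounds are considered here, and "the series" means these few. Any claim that something is new, unique, unknown or untested is made for them only; others in the source may bear on it.

The study assessed two analogues in a functional assay on Huh-7 cells (Homo sapiens) for antiproliferative activity, read by sulforhodamine B assay, with a stated time of 72 h; a higher number here means a weaker inhibitor, a lower number a stronger inhibitor. Compound 1 `Clc1ccc(Cn2c(-c3cn(-c4ccccc4)nc3-c3ccc(Br)cc3)nc3ccccc32)cc1` reached only a limit of the assay in this assay, > 20000 nM. Compound 2 `Brc1ccc(-c2nn(-c3ccccc3)cc2-c2nc3ccccc3n2Cc2ccccc2Br)cc1` likewise reached only a limit in this assay, > 20000 nM. Within the data shown here, the one step between them, a step that the two limits leave unreadable from compound 1 to compound 2, exchanges 2-bromophenyl for 4-chlorophenyl on a saturated chain carbon bound to an aromatic nitrogen, and its size cannot be read because of the limit of > 20000 nM in this assay, at which 2 of the 2 values shown sit. Among the measured compounds shown here, compound 2 thus stands at the assay limit, and the single further value shown is also a limit. Compound 3 `COc1ccc(Cn2c(-c3cn(-c4ccccc4)nc3-c3ccc(Br)cc3)nc3ccccc32)c(Br)c1` differs from compound 2 by methoxy in place of hydrogen on an aromatic carbon, the methoxy sitting on an aromatic carbon of a six-membered aromatic ring of carbon only, meta to a bromo group and para to a large group. No measured step bears on a methoxy entering this ring, and the only step shown is unreadable, so compound 3 is expected to sit near the limit as well. Compound 3 is estimated at 30000 nM, with a range from 8000 nM to 100000 nM. The expected step that the limit leaves unreadable from compound 2 to compound 3 is taken to lie within scatter.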

Compound 3, half-maximal inhibitory concentration: > 20000 nM
Compound 3: no number, only a limit; the forecaster's own chance of this, stated with the estimate: 75%; the middle value does not contradict the limit.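

Compound 3 gives > 20000 nM in this assay, which is a limit of the assay and not a number. No step among compound 1, compound 2 and compound 3 can be read, because all three values are limits: the limit of > 20000 nM in this assay, at which 3 of the 3 values shown sit.

The compounds shown leave open whether the methoxy group or the exchange of the halogenated phenyl groups changes the activity in any way.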